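The source may hold more compounds than are shown below. What is called first, only, known or untested is meant among the compounds shown, and "the series" means these compounds.

Measured in a functional assay on A2780 cells (Homo sapiens) for inhibition; a higher number here means a weaker inhibitor, a lower number a stronger inhibitor:

- Compound 1 `CC(C(=O)Nc1cc(C2CC2)[nH]n1)c1ccc(N2C(=O)CCC2C)cc1`: 6400 nM
- Compound 2 `C[C@H](C(=O)Nc1cc(C2CC2)[nH]n1)c1ccc(N2CCCC2)cc1`: 220 nM
- Compound 3 `CC(C(=O)Nc1cc(C2CC2)[nH]n1)c1ccc(N2Cc3ccccc3C2=O)cc1`: 4750 nM

Compound 3, at 4750 nM, lies within the usual scatter of compound 1, so these two cannot be told apart. Compound 2 has a much lower number, beyond the scatter, which marks it as the stronger inhibitor of the three.

The next compound is compound 4 `C[C@H](C(=O)Nc1cc(C2CC2)[nH]n1)c1ccc(N2Cc3ccccc3C2=O)cc1`. the two compounds have the same atoms and bonds; at least one stereo element is drawn with a configuration in one of them and without one in the other: 1 of 1 stereo elements differ; a stereocentre at a saturated chain carbon is drawn without a configuration in compound 3 and S in compound 4 A stereocentre at a saturated chain carbon is drawn without a configuration in compound 3 and S in compound 4, while the atoms and bonds stay the same.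

Going by the values given here, no measured pair shows what such a change does in this assay. Compound 2, at 220 nM, is drawn S at this carbon, but it also differs from compound 3 in another part of the structure, so it offers only a weak hint. A small move towards a lower number seems most likely, about the size of the scatter. The expected step is a 1.9-fold lower number from compound 3 to compound 4 (0.28 log units; within the scatter). For compound 4 the estimated value is 2500 nM, with an expected range from 1000 nM to 6000 nM.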

Compound 4, half-maximal inhibitory concentration: 1020 nM
For compound 4 the middle estimate is 2.5-fold (0.39 log units) above the measured one; measured number inside the range.
By their numbers in this assay, from the lowest: compound 2; then compound 4; then compounds 3 and 1 (each within the scatter of the next).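

Setting the saturated chain carbon to S, with no other change to the structure, gives a 4.7-fold lower number from compound 3 to compound 4 (0.67 log units; beyond the scatter) in this assay. Going by these compounds alone, this is the first pair here that isolates this carbon, and it shows that its drawn configuration alone can move the number by more than the usual scatter, which compound 2 could only hint at. The step can be assigned to this one carbon because nothing else separates the two structures: the fact that one of compounds 3 and 4 is drawn with a defined configuration and the other without, at the place where they differ.

The compounds shown do not reveal how the R configuration at this carbon would compare, nor whether compound 1 would shift in the same way if drawn as S. They also leave open what an ethyl group in place of the methyl on this carbon would do to the number.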